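Dimethylpyrazolyl to dimethylimidazolyl exchange on compound 3

The compounds below may be only part of what the source reports. "The series", "measured", "known", "first", "only" and "open" are said of these compounds alone.

In a physicochemical assay for solubility, in phosphate buffer, at pH 7.4 (a lower number here means a less soluble compound, a higher number a more soluble compound), compound 1 `CC(=O)N[C@@H]1CCC[C@H](C(=O)Nc2cc(-c3cnc(C)n3C(C)C)ccn2)C1` gives 660000 nM, compound 2 `CC(=O)N[C@@H]1CCC[C@H](C(=O)Nc2cc(-c3cnn4c3CCCC4)ccn2)C1` gives 730000 nM and compound 3 `CC(=O)N[C@@H]1CCC[C@H](C(=O)Nc2cc(-c3cnn(C)c3C)c(Cl)cn2)C1` gives 960000 nM. The gaps from compound 3 to the other two are within the scatter, so the three values stand level and compound 3 has no separate place among them.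

Compound 4 `CC(=O)N[C@@H]1CCC[C@H](C(=O)Nc2cc(-c3cnc(C)n3C)c(Cl)cn2)C1` differs from compound 3 in a single group: 1,2-dimethyl-1H-imidazol-5-yl in place of 1,5-dimethyl-1H-pyrazol-4-yl on an aromatic carbon. The new group, 1,2-dimethyl-1H-imidazol-5-yl, takes the place of 1,5-dimethyl-1H-pyrazol-4-yl on the same aromatic carbon, ortho to a chloro group and opposite the ring nitrogen. The two compounds have the same atoms, joined differently.

No measurement covers this exact exchange. The nearest evidence is a 1.1-fold higher number from compound 1 to compound 2 (0.04 log units; within the scatter), which also replaces one group on an aromatic carbon and stays within the scatter. Going by the values given here, with only that one step to go on, no change beyond the scatter is expected in this assay, and no direction can be argued with confidence. The expected step, a 1.1-fold lower number from compound 3 to compound 4 (0.05 log units; within the scatter), is an estimate that allows for the level of compound 3 at 960000 nM and the close values of the other two compounds. The estimated value for compound 4 is 850000 nM, with an expected range of 450000 nM to 1400000 nM.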

Compound 4, solubility: > 1000000 nM
Compound 4: no number, only a limit (the forecaster's own chance of this, stated with the estimate: 15%); middle value at least 1.1-fold (0.07 log units) away from the limit.
By their numbers in this assay, from the lowest: compounds 1, 2 and 3 (each within the scatter of the next). At a limit, above all of these: compound 4.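

Going by these compounds alone, this is the first exchange between two groups made of the same atoms, 1,2-dimethyl-1H-imidazol-5-yl in place of 1,5-dimethyl-1H-pyrazol-4-yl, on the aromatic carbon ortho to a chloro group. In this assay compound 4 gives > 1000000 nM, which is a limit of the assay and not a number. The step reads an at least 1.0-fold higher number from compound 3 to compound 4 (0.01 log units; that floor lies within the scatter), so rejoining the same atoms at this position shows no loss, while the size of any gain stays unread and the result marks only the top of the readable range: the limit of > 1000000 nM in this assay, at which 1 of the 4 values shown sits.

Still open is how far compound 4 lies past that limit, and whether the 1,2-dimethyl-1H-imidazol-5-yl group would read the same without the chloro group, as no pair shown differs in that one place. Also open, as far as these compounds go, is how this assay responds at this position to a group of another kind, such as an amine or a carboxylic acid on the five-membered ring, or a longer chain in place of either methyl group.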